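Amino in place of hydrogen on a compound at limit

A few compounds are considered here, and "the series" means these few. Any claim that something is new, unique, unknown or untested is made for them only; others in the source may bear on it.

In a functional assay on CCRF-CEM cells (Homo sapiens), read by MTT assay, with a stated time of 72 h (a higher number here means a weaker inhibitor, a lower number a stronger inhibitor), compound 1 (`COc1ncnc2c1c(-c1ccccc1)cn2[C@@H]1O[C@H](CO)[C@@H](O)[C@H]1O`) gives > 20000 nM as a limit and not a number. Compound 2 (`CSc1ncnc2c1c(-c1ccccc1)cn2[C@@H]1O[C@H](CO)[C@@H](O)[C@H]1O`) gives > 20000 nM as a limit too. Compound 3 (`CNc1ncnc2c1c(-c1ccccc1)cn2[C@@H]1O[C@H](CO)[C@@H](O)[C@H]1O`) gives > 20000 nM as a limit too.

Compound 4 (`COc1nc(N)nc2c1c(-c1ccccc1)cn2[C@@H]1O[C@H](CO)[C@@H](O)[C@H]1O`) keeps the methoxy group of compound 1 and carries amino in place of hydrogen on an aromatic carbon between two ring nitrogen atoms (amino in place of hydrogen on an aromatic carbon). The measured steps bear on this only indirectly, since they exchange methoxy, methylsulfanyl and methylamino and leave this carbon untouched. None of them has a readable size: (a step that the two limits leave unreadable from compound 1 to compound 2), (a step that the two limits leave unreadable from compound 1 to compound 3) and (a step that the two limits leave unreadable from compound 2 to compound 3).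

For the measured compounds named here, with compound 1 at the limit of > 20000 nM in this assay, at which 3 of the 3 values shown sit, and no tested compound carrying this amino group, no step beyond the scatter is expected in this assay in either direction. For compound 4 the expected step is (a number no higher from compound 1 to compound 4 (the limit leaves the size open)). Compound 4 is estimated at 20000 nM with an expected range from 8000 nM to 40000 nM. Compound 4 may well give only a limit.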

Compound 4, half-maximal inhibitory concentration: > 20000 nM
Compound 4 ended at the assay's limit (the forecaster's own chance of this, stated with the estimate: 80%); the middle value lies on the limit itself.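

Compound 1 and compound 4 both end at a limit of the assay and not at a number, so no size can be read for the step between them: the limit of > 20000 nM in this assay, at which 4 of the 4 values shown sit.

The compounds shown leave open whether amino in place of hydrogen changes potency in this assay, and how the four compounds rank.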